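Bromo to fluoro on the shared core

The source may hold more compounds than are shown below. What is called first, only, known or untested is meant among the compounds shown, and "the series" means these compounds.

In a functional assay on B16-F10 cells (Mus musculus) for inhibition, read by MTT assay, with a stated time of 72 h (on this read-out higher numbers stand for weaker inhibition and lower numbers for stronger inhibition), compound 1 (`COc1ccc(NC(=S)NC2CC(C)(C)Oc3ccc(Br)cc32)cc1`) stands as "not determined" (no result reported) and offers no comparison. Among the measured compounds shown here, compound 2 (`CC1(C)CC(NC(=S)Nc2cccc(C#N)c2)c2cc(Br)ccc2O1`) gives 7000 nM as the only number, so it cannot yet be ranked. Compound 3 (`CC1(C)CC(NC(=S)Nc2cccc(C#N)c2)c2cc(F)ccc2O1`) differs from compound 2 in one place: fluoro in place of bromo on an aromatic carbon. For the measured compounds named here, no measured step is available to size this change. The expected 1.4-fold higher number from compound 2 to compound 3 (0.15 log units; within the scatter) in this assay stays within the usual scatter and leans slightly towards weaker inhibition. For compound 3 the estimate is 10000 nM with an expected range from 4000 nM to 30000 nM as a working figure.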

Compound 3, half-maximal inhibitory concentration: 35000 nM
Compound 3: the middle estimate sits 3.5-fold (0.54 log units) below what was measured, outside the stated range (above it).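

Changing this aromatic carbon from bromo to fluoro has a measurable effect in this assay, with a 5.0-fold higher number from compound 2 to compound 3 (0.70 log units; beyond the scatter). This first measured step in the series shows weaker inhibition with fluoro than with bromo at this position, with the nitrile-bearing side of the thiourea unchanged. Nothing measured here explains the loss. From the compounds shown here alone, whether a chloro, methyl or methoxy group at this carbon would fall between or beyond bromo and fluoro remains open. Also open, going by these compounds, is whether the same change would carry over to other aryl groups on the thiourea.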